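Series notes: amide substituent on the shared core

This account rests on a few compounds, and the source may have more. Where it says the series, first, only, none or still open, it means among the compounds named here.

The shared core of compound 1 `CC1CCN(C(=O)C(C)N2CCN(S(=O)(=O)c3ccc(C(C)(C)C)cc3)CC2)CC1` carries a 4-methylpiperidin-1-yl amide. In an ADME assay on HepG2 cells (Homo sapiens) for inhibition, with a stated time of 48 h (on this read-out lower numbers stand for an effect already at smaller amounts and higher numbers for an effect only at larger amounts of compound), compound 1 gives only a limit of > 40000 nM. Compound 2 `CC(C(=O)N1CCOCC1)N1CCN(S(=O)(=O)c2ccc(C(C)(C)C)cc2)CC1` carries a morpholin-4-yl amide in its place. In this assay compound 2 likewise gives only a limit of > 40000 nM. The step that the two limits leave unreadable from compound 1 to compound 2 cannot be read, because both values sit at the limit of > 40000 nM in this assay, at which 2 of the 2 values shown sit, so where compound 2 stands in this assay is known only as being at that limit.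

Compound 3 `CC(C(=O)N1CCN(C)CC1)N1CCN(S(=O)(=O)c2ccc(C(C)(C)C)cc2)CC1` is the next member. Its change from compound 2 is 4-methylpiperazin-1-yl in place of morpholin-4-yl on a carbonyl carbon. For the measured compounds named here, the only measured step, the one from compound 1 to compound 2, is a change at the same carbonyl carbon and is unreadable; nothing else bears on the present change. No step beyond the scatter is therefore expected, and compound 3 is expected to give again a limit rather than a number. For compound 3 in this assay the estimate is 60000 nM, within 15000 nM to 200000 nM. The expected step is a step that the limit leaves unreadable from compound 2 to compound 3, within the scatter.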

Compound 3, half-maximal effective concentration: > 40000 nM
Compound 3 was reported as a limit; the forecaster's own chance of this, stated with the estimate: 80%; the middle value is on the limit's open side.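

No new step can be read among compound 1, compound 2 and compound 3 in this assay, since all three values are limits: the limit of > 40000 nM in this assay, at which 3 of the 3 values shown sit.

The compounds shown leave open whether the 4-methylpiperidin-1-yl, morpholin-4-yl and 4-methylpiperazin-1-yl amides differ at all on the shared core, and where each compound's actual half-maximal effective concentration lies.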